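Ether-bearing ring in place of cyclobutyl on the amine side chain

The source may report more compounds than this note shows. Statements on the series, on what has been measured and on what is new or still open speak of the compounds shown alone.

Measured compounds:
compound 1, `COc1cccc(-n2cc3nc(-c4cccnc4C)n(C[C@H]4CCCN(CC5CCC5)C4)c(=O)c3n2)c1`, 1.6 nM
compound 2, `Cc1ncccc1-c1nc2cn(-c3ccccc3)nc2c(=O)n1C[C@H]1CCCN(C[C@H]2CCCO2)C1`, 190 nM

In an assay on HEK293 cells for displacement of a labelled ligand from growth hormone secretagogue receptor type 1 (Homo sapiens), with a stated time of 60 min (on this read-out lower numbers stand for stronger inhibition and higher numbers for weaker inhibition), compound 1 gives 1.6 nM, the lowest of the two numbers shown. Among the measured compounds shown here, compound 2 gives 190 nM in this assay, a far higher number, but compound 2 differs from compound 1 in more than one place, so the two values say only that compound 2 is much weaker. Compound 3, `COc1cccc(-n2cc3nc(-c4cccnc4C)n(C[C@H]4CCCN(CC5CCCCO5)C4)c(=O)c3n2)c1`, differs from compound 1 in one place: oxan-2-yl in place of cyclobutyl on a saturated chain carbon bound to an amine nitrogen in a ring. For the measured compounds named here, no measured pair shows this change on its own, so its effect is unknown. A small step toward a higher number, or none beyond the scatter, is expected for a 2.5-fold higher number from compound 1 to compound 3 (0.40 log units; beyond the scatter). Compound 3 is therefore estimated at 4 nM in this assay, with a range from 1.5 nM to 12 nM.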

Compound 3, half-maximal inhibitory concentration: 120 nM
Compound 3: middle estimate off by 30-fold (1.48 log units), on the low side, outside the stated range (above it).
By their numbers in this assay, from the lowest: compound 1; then compounds 3 and 2 (each within the scatter of the next).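

In this assay, replacing cyclobutyl with oxan-2-yl on a saturated chain carbon bound to an amine nitrogen in a ring gives a 75-fold higher number from compound 1 to compound 3 (1.88 log units; beyond the scatter), with the rest of compound 1 unchanged. Among the compounds shown here, this is the first reading of this position on its own: compound 2 could not provide one, as it differs from compound 1 in more than one place, whereas this single change shows that the group here has a large bearing on the value in this assay. No measurement shown accounts for the size of this step.

The change brings in a larger ring and a ring oxygen at once, and the compounds shown leave open which of the two goes with the higher number. A cyclohexyl group or an oxetan-2-yl group at this place would separate them.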